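The source may hold more compounds than are shown below. What is called first, only, known or untested is meant among the compounds shown, and "the series" means these compounds.

In an ADME assay on L6 cells (Rattus norvegicus) for cytotoxicity, read by resazurin assay, with a stated time of 72 h (on this read-out lower numbers stand for stronger inhibition and higher numbers for weaker inhibition), compound 1 `NC(=O)c1cccc(C(O)(c2ccc(Cl)cc2)c2cccnc2)c1` gives > 100000 nM, which is a limit of the assay. Compound 2 `NC(=O)c1cccc(C(O)(c2ccc(C(F)(F)F)cc2)c2cccnc2)c1` gives > 100000 nM, also a limit. Among the measured compounds shown here, the series so far stands at the limit of > 100000 nM in this assay, at which 2 of the 2 values shown sit, and the one measured change is a step that the two limits leave unreadable from compound 1 to compound 2. Compound 3 `OC(c1ccc(C(F)(F)F)cc1)(c1cccnc1)c1cc2ccccc2s1` differs from compound 2 by 1-benzothiophen-2-yl in place of 3-carbamoylphenyl on a saturated chain carbon bound to two aromatic carbons and an oxygen on a saturated carbon. For the measured compounds named here, no measured step covers this replacement, so the expectation rests on the limit of compound 2 alone: a move toward stronger inhibition in this assay, of uncertain size. For compound 3 the estimated value is 40000 nM, with an expected range of 10000 nM to 100000 nM. The expected change is an at least 2.5-fold lower number from compound 2 to compound 3 (0.39 log units; beyond the scatter).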

Compound 3, half-maximal inhibitory concentration: 58700 nM
Beside the measured number, compound 3's estimate is 1.5-fold (0.17 log units) below it; the measured number falls inside the stated range.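

The change at this position, 1-benzothiophen-2-yl in place of 3-carbamoylphenyl, gives an at least 1.7-fold lower number from compound 2 to compound 3 (0.23 log units; that floor lies within the scatter). The value of compound 2 is a limit, so this step is only a floor and its true size cannot be read. Compound 3 is the first compound with a readable number in this assay, while the other compounds remain at the limit: the limit of > 100000 nM in this assay, at which 2 of the 3 values shown sit.

As far as these compounds go, whether the second aromatic ring or the loss of the carbamoyl group carries the step stays open. Also open, from the compounds shown here alone, is how 3-aminophenyl or 3-carboxyphenyl would read at this place.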